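The source may hold more compounds than are shown below. What is called first, only, known or untested is meant among the compounds shown, and "the series" means these compounds.

In a functional assay for inhibition, read by Griess assay, with a stated time of 150 min, tested at 1 mM (on this read-out higher numbers stand for more inhibition at the one concentration tested (going by the name of the read-out) and lower numbers for less inhibition), compound 3 `COc1ccc(/C(Cl)=C/C=C(\C#N)C(=O)c2c[nH]c3ccc(OC)cc23)cc1` gives 41.6%, the lowest of the three numbers measured. Compound 1 `COc1ccc(/C(Cl)=C/C=C(\C#N)C(=O)c2c[nH]c3ccc(Br)cc23)cc1OC` gives 57.5%, and compound 2 `COc1ccc(/C(Cl)=C/C=C(\C#N)C(=O)c2c[nH]c3ccccc23)cc1OC` gives 75%; both sit above compound 3 by more than the usual scatter. Going by the values given here, the only step measured between two compounds differing in a single place, a number 17.5 percentage points higher from compound 1 to compound 2 (beyond the scatter), concerns an exchange on the shared core and not the ring changed here. Compound 4 `COc1ccc2[nH]cc(C(=O)/C(C#N)=C/C=C(\Cl)c3ccc(OC)c(OC)c3)c2c1` differs from compound 3 by methoxy in place of hydrogen on an aromatic carbon, turning 4-methoxyphenyl into 3,4-dimethoxyphenyl. Among the compounds with values here, no measured step addresses that change, so its direction is uncertain, and the step of a number 8.4 percentage points higher from compound 3 to compound 4 (within the scatter) is expected to stay within or close to the scatter. Compound 4 is expected to give about 50%, most likely between 35% and 65%.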

Compound 4, a percentage reported as inhibition, at one concentration (the size of the read-out at that concentration, not a potency): 74.2%
Estimate against measurement, compound 4: 24.2 percentage points below; measured number above the stated range.
By their numbers in this assay, from the lowest: compound 3; then compound 1; then compounds 4 and 2 (each within the scatter of the next).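

In this assay, the added methoxy that turns 4-methoxyphenyl into 3,4-dimethoxyphenyl has a large effect on the number (a number 32.6 percentage points higher from compound 3 to compound 4 (beyond the scatter)). With 3,4-dimethoxyphenyl kept, methoxy and hydrogen on the shared core cannot be told apart (a number 0.8 percentage points lower from compound 2 to compound 4 (within the scatter)), whereas methoxy in place of bromo there gives a higher number (a number 16.7 percentage points higher from compound 1 to compound 4 (beyond the scatter)). No measurement at hand explains these steps. Going by these compounds, whether a hydroxyl or an amine in place of the added methoxy would hold the number stays open. So does whether that methoxy counts as much with hydrogen or bromo on the core.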